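The source may hold more compounds than are shown below. What is called first, only, known or untested is meant among the compounds shown, and "the series" means these compounds.

Measured in a functional assay on the whole organism (stomach) with Rattus norvegicus as the target; on this read-out higher numbers stand for an effect only at larger amounts of compound and lower numbers for an effect already at smaller amounts:

- Compound 1, `CN(C)/C(=N/CCCCn1nc(-c2ccccc2)ccc1=O)NC#N`: compound 1 gives 30.3 mg/kg.
- Compound 2, `CC/N=C(/NC#N)NCCCn1nc(C)ccc1=O`: compound 2 reaches only a limit, > 100 mg/kg.
- Compound 3, `C/N=C(/NC#N)NCCCCn1nc(-c2ccc(C)cc2)ccc1=O`: compound 3 likewise reaches only a limit, > 100 mg/kg.

Of the three compounds tested in this assay, compound 1 is the only one for which a real number was obtained; the other two sit at the limit of > 100 mg/kg in this assay, at which 2 of the 3 values shown sit. For the measured compounds named here, compound 1 is therefore the sole fixed point from which anything about a new analogue can be reasoned, and no single-change pair among the measured compounds gives a step size to lean on.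

Compound 4, `N/C(S)=N/CCCCn1nc(-c2ccccc2)ccc1=O`, differs from compound 1 in one place: a group of 4 heavy atoms (1 carbon, 2 nitrogen, 1 sulfur; no ring) in place of a group of 8 heavy atoms (4 carbon, 4 nitrogen; no ring), on a saturated chain carbon, four bonds along the chain from an aromatic nitrogen. The shared core and the four-carbon chain stay the same; only the group at the end of the chain is exchanged, a thiourea in place of the cyanoguanidine.

Going by the values given here, with no measured step of this kind, the safest expectation is a change in this assay that is small or modest, leaning toward a somewhat larger dose, since two of three compounds in this set only reach the limit. Compound 4 is expected to give about 45 mg/kg, within a range from 12 mg/kg to 150 mg/kg, which corresponds to an estimated step of a 1.5-fold higher number from compound 1 to compound 4 (0.17 log units; within the scatter).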

Compound 4, dose for half-maximal effect: 36.3 mg/kg
For compound 4 the middle estimate is 1.2-fold (0.09 log units) above the measured one, within the range that was stated.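

Exchanging the cyanoguanidine at the end of the four-carbon chain for a thiourea gives, in this assay, a 1.2-fold higher number from compound 1 to compound 4 (0.08 log units; within the scatter). For the compounds shown here, this is the first single-change step in the set, and it shows that at this place, on a saturated chain carbon, four bonds along the chain from an aromatic nitrogen, a group of 4 heavy atoms with a sulfur and without a nitrile can stand in for the group of 8 heavy atoms with no difference beyond the scatter, so the full cyanoguanidine is not needed for a real number on this read-out. Compound 2 and compound 3 still give only a limit of the assay, not a number, so neither can yet be set against this step: the limit of > 100 mg/kg in this assay, at which 2 of the 4 values shown sit.

The compounds shown leave open whether other end groups on the same chain, such as a urea, a simple amine or a carboxylic acid, would also keep a real number. They also leave open whether the same exchange gives as small a step on a shorter or longer chain, or on a core carrying a different group in place of the phenyl.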